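Swapping Benzoyloxy for Trifluoromethyl: an Expected Gain

The source may hold more compounds than are shown below. What is called first, only, known or untested is meant among the compounds shown, and "the series" means these compounds.

In a functional assay (muscle tissue) with Cavia porcellus as the target (a lower number here means that less compound is needed, a higher number that more compound is needed for the effect), compound 1 `COC(=O)C1=C(C)N=C(C)/C(=C(\O)OC)C1c1cccc(OC(=O)c2ccccc2)c1` gives 6310 nM, the highest of the three values measured, so it needs the most compound of the three for the effect. Compound 2 `COC(=O)C1=C(C)N=C(C)/C(=C(\O)OC)C1c1ccccc1I` gives 46.8 nM, and compound 3 `COC(=O)C1=C(C)N=C(C)/C(=C(\O)OC)C1c1c(F)c(F)c(F)c(F)c1F` gives 4.37 nM; both gaps to compound 1 lie well beyond the usual scatter. Compound 4 `COC(=O)C1=C(C)N=C(C)/C(=C(\O)OC)C1c1cccc(C(F)(F)F)c1` has not yet been measured in this assay. It differs from compound 1 in one place: trifluoromethyl in place of benzoyloxy on an aromatic carbon. Among the compounds with values here, no measured pair shows this exact exchange, so the expectation rests on compounds 2 and 3, which carry different groups on the aromatic ring and need far less compound than compound 1. A large drop is expected, a 210-fold lower number from compound 1 to compound 4 (2.32 log units; beyond the scatter). Compound 4 is therefore estimated at 30 nM, with a likely range from 5 nM to 200 nM.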

Compound 4, half-maximal effective concentration: 74.1 nM
Compound 4: the middle estimate sits 2.5-fold (0.39 log units) below what was measured; the measured number falls inside the stated range.
By their numbers in this assay, from the lowest: compound 3; then compounds 2 and 4 (each within the scatter of the next); then compound 1.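

Within the data shown here, putting trifluoromethyl in place of benzoyloxy on this aromatic carbon gives an 85-fold lower number from compound 1 to compound 4 (1.93 log units; beyond the scatter) in this assay and is the first direct reading of this exchange at this place. The extra aromatic ring and the two oxygens of benzoyloxy are therefore not needed for the effect, and the much smaller group needs far less compound. No measurement available here explains why the number falls so far.

From the compounds shown here alone, whether a methoxy group, an amine or a carboxylic acid on the same carbon would behave like trifluoromethyl stays open. So does whether a plain phenyl ring there, without the oxygens of benzoyloxy, would need as much compound as compound 1.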